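Thiophene isomers on a weak aryl ester scaffold

The source may report more compounds than this note shows. Statements on the series, on what has been measured and on what is new or still open speak of the compounds shown alone.

Compound 1, `CCOC(=O)c1ccnc(-c2ccc(OCC)cc2)c1`: 80000 nM
Compound 2, `CCOC(=O)c1cccc(-c2ccc(OCC)cc2)c1`: 50000 nM
Compound 3, `CCOC(=O)c1cccc(-c2ccsc2)c1`: 75000 nM

All three compounds were tested in an assay on COS-7 cells for inhibition of patatin-like phospholipase domain-containing protein 2 (Mus musculus) (a lower number here means a stronger inhibitor, a higher number a weaker inhibitor), and all three are weak. Compound 3 stands second highest of the three numbers; its nearest neighbour is compound 1 and its furthest is compound 2, and both gaps lie within the usual scatter of this assay, so the three compounds cannot be told apart on these numbers.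

Compound 4, `CCOC(=O)c1cccc(-c2cccs2)c1`, has not been measured. It differs from compound 3 by thiophen-2-yl in place of thiophen-3-yl on an aromatic carbon. Going by the values given here, no step between two measured compounds is available to guide the size of this change, and the three measured compounds themselves show no separation beyond the scatter. For that reason the swap of one thiophene attachment for the other is expected to give no step beyond the scatter, in no particular direction.

Compound 4 is therefore expected near 70000 nM, with a range from 30000 nM to 160000 nM. The expected 1.1-fold lower number from compound 3 to compound 4 (0.03 log units; within the scatter) is accordingly one that stays within the scatter.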

Compound 4, half-maximal inhibitory concentration: 90000 nM
The estimate for compound 4 lay 1.3-fold (0.11 log units) below the measured number, and the stated range covers the measured number.
By their numbers in this assay, from the lowest: compounds 2, 3, 1 and 4 (each within the scatter of the next).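

In this assay, thiophen-2-yl in place of thiophen-3-yl on an aromatic carbon meta to an ethoxycarbonyl group gives a 1.2-fold higher number from compound 3 to compound 4 (0.08 log units; within the scatter). Going by these compounds alone, this is the first step that isolates one change at one place, and it lies within the scatter, so the two thiophene attachments cannot be told apart at this position. Nothing available bears on why the two attachments give numbers so close together.

On these data alone, whether any change at this position can give a step beyond the scatter remains open, for example an amine or a longer chain in place of the thiophene. As far as these compounds go, it is equally open whether a carboxylic acid in place of the ethoxycarbonyl group would separate from these compounds.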